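A few compounds are considered here, and "the series" means these few. Any claim that something is new, unique, unknown or untested is made for them only; others in the source may bear on it.

Of the compounds shown here, three built on one shared core have been measured in a functional assay on cells (Lymphocyte, Homo sapiens); a higher number here means a weaker inhibitor, a lower number a stronger inhibitor. Compound 1 `Nc1nc(N2CCN(C(=O)COc3ccc(Cl)cc3)CC2)c2nc(-c3ccc(F)cc3)sc2n1` gives 490 nM, the highest of the three numbers. Compound 2 `Cc1cccc(NC(=O)N2CCN(c3nc(N)nc4sc(-c5ccc(F)cc5)nc34)CC2)c1` gives 300 nM, and the step of a 1.6-fold lower number from compound 1 to compound 2 (0.21 log units; within the scatter) stays within the scatter. Compound 3 `Nc1nc(N2CCN(C(=O)COc3ccccc3)CC2)c2nc(-c3ccc(F)cc3)sc2n1` gives 90 nM; the step of a 5.4-fold lower number from compound 1 to compound 3 (0.74 log units; beyond the scatter) lies beyond the scatter, as does the step of a 3.3-fold lower number from compound 2 to compound 3 (0.52 log units; beyond the scatter). Among the measured compounds, compound 2 stands nearest to compound 1 and compound 3 furthest from it.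

Compound 4 `COc1ccc(OCC(=O)N2CCN(c3nc(N)nc4sc(-c5ccc(F)cc5)nc34)CC2)cc1` differs from compound 1 in one place: methoxy in place of chloro on an aromatic carbon. For the measured compounds named here, the only measured step that touches the same part of the molecule is a 5.4-fold lower number from compound 1 to compound 3 (0.74 log units; beyond the scatter), where taking the chloro away gave a modest gain. As far as these compounds go, nothing measured shows a methoxy there, so whether it behaves more like hydrogen or more like chloro is unknown. The step of a 1.6-fold lower number from compound 1 to compound 2 (0.21 log units; within the scatter) and the step of a 3.3-fold lower number from compound 2 to compound 3 (0.52 log units; beyond the scatter) concern a different part of the molecule and bear only indirectly. A gain somewhat smaller than that seen for compound 3 is expected, so the step of a 2.2-fold lower number from compound 1 to compound 4 (0.35 log units; beyond the scatter) is estimated to fall between no change and the gain seen for compound 3. Compound 4 is therefore expected to give about 220 nM in this assay, within a range from 90 nM to 550 nM.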

Compound 4, half-maximal inhibitory concentration: 40 nM
Estimate against measurement, compound 4: 5.5-fold (0.74 log units) above; the whole stated range lies above it.
By their numbers in this assay, from the lowest: compound 4; then compound 3; then compounds 2 and 1 (each within the scatter of the next).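

In this assay, for the compounds shown here, compound 4 changes the reading of the position para to a large group: the earlier compounds showed only that taking chloro away helped, which left open whether any group there would cost activity. With methoxy, the step is larger, a 12-fold lower number from compound 1 to compound 4 (1.09 log units; beyond the scatter), and the number also falls relative to the unsubstituted ring, a 2.3-fold lower number from compound 3 to compound 4 (0.35 log units; beyond the scatter), so a group at this place can do better than hydrogen, and what matters is which group it is, not merely whether one is present. The phenoxymethyl side also moves further from the (3-methylphenyl)amino side, with a 7.5-fold lower number from compound 2 to compound 4 (0.88 log units; beyond the scatter) against a 3.3-fold lower number from compound 2 to compound 3 (0.52 log units; beyond the scatter), though nothing available explains why methoxy and chloro differ so widely at this position.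

As far as these compounds go, what remains open is whether an ethoxy, a hydroxyl or a dimethylamino group at the same place would keep or extend this result, or whether it is specific to methoxy. From the compounds shown here alone, it is also open whether methoxy would act the same way elsewhere on this ring, or on the aromatic ring of the (3-methylphenyl)amino group in compound 2.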